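This account rests on a few compounds, and the source may have more. Where it says the series, first, only, none or still open, it means among the compounds named here.

Compound 1 `CCC(=O)N1C[C@@H](O[C@H](C)c2cc(C(F)(F)F)cc(C(F)(F)F)c2)[C@H](c2ccc(F)cc2)C1` gives 0.09 nM in an assay on CHO cells for displacement of a labelled ligand from Substance-P receptor (Homo sapiens); on this read-out lower numbers stand for stronger inhibition and higher numbers for weaker inhibition. Among the three compounds measured there it holds the second highest number: compound 3 `CC(C)NC(=O)N1C[C@@H](O[C@H](C)c2cc(C(F)(F)F)cc(C(F)(F)F)c2)[C@H](c2ccc(F)cc2)C1`, at 0.06 nM, lies nearest, a 1.5-fold lower number from compound 1 to compound 3 (0.18 log units; within the scatter), while compound 2 `C[C@@H](O[C@@H]1CN(C(=O)N(C)C)C[C@H]1c1ccc(F)cc1)c1cc(C(F)(F)F)cc(C(F)(F)F)c1`, at 0.38 nM, lies furthest, a 4.2-fold higher number from compound 1 to compound 2 (0.63 log units; beyond the scatter). Compound 4 `C[C@@H](O[C@@H]1CN(C2=CC(=O)OC2)C[C@H]1c1ccc(F)cc1)c1cc(C(F)(F)F)cc(C(F)(F)F)c1` differs from compound 1 by a group of 6 heavy atoms (4 carbon, 2 oxygen; one five-membered non-aromatic ring with 1 hetero atom) in place of a group of 4 heavy atoms (3 carbon, 1 oxygen; no ring), on an amine nitrogen in a ring. Among the measured compounds shown here, no measured step removes the whole propanoyl; the steps that bear on it exchange only the group on its carbonyl carbon, and even the largest of them, a 6.3-fold lower number from compound 2 to compound 3 (0.80 log units; beyond the scatter), remains modest. Compound 4 is therefore expected to show a 2.2-fold higher number from compound 1 to compound 4 (0.35 log units; beyond the scatter), with no step beyond the scatter. For compound 4 the estimate in this assay is 0.2 nM, expected to fall between 0.05 nM and 0.8 nM.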

Compound 4, half-maximal inhibitory concentration: 0.16 nM
The estimate for compound 4 lay 1.3-fold (0.10 log units) above the measured number; low and high end bracket the measured number.
By their numbers in this assay, from the lowest: compounds 3, 1 and 4 (each within the scatter of the next, the first and the last beyond it); then compound 2.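

In this assay, among the compounds shown here, the earlier compounds changed only the group on the carbonyl carbon, whereas here the whole propanoyl gives way to a group with a five-membered non-aromatic ring, with a 1.8-fold higher number from compound 1 to compound 4 (0.25 log units; within the scatter) at the amine nitrogen in a ring. Set against the other two, the same group gives a 2.7-fold higher number from compound 3 to compound 4 (0.43 log units; beyond the scatter) and a 2.4-fold lower number from compound 2 to compound 4 (0.38 log units; beyond the scatter) at this place, so compound 4 falls inside the range of the earlier three. Nothing shown gives a reason for these steps.

From the compounds shown here alone, whether an acetyl, a longer acyl chain or a ring bearing an amine would stay in this range remains open.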